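The source may report more compounds than this note shows. Statements on the series, on what has been measured and on what is new or still open speak of the compounds shown alone.

Among the compounds with values here, in a functional assay on SK-MEL-147 cells (Homo sapiens) for cytotoxicity, read by MTT assay, with a stated time of 24 h (a higher number here means that more compound is needed for the effect, a lower number that less compound is needed), compound 1 (`CCOC(=O)c1cc([Se]c2ccccc2)c2cc(OC)ccc2n1`) gives 33000 nM as the lower of the two numbers measured so far. Compound 2 (`CCOC(=O)c1cc([Se]c2ccccc2)c2ccccc2n1`) has hydrogen in place of methoxy on an aromatic carbon and gives 86300 nM in this assay as the other number. Still unmeasured is compound 3 (`COc1ccc2nc(-c3c(Cl)cccc3Cl)cc([Se]c3ccccc3)c2c1`), which keeps the methoxy group of compound 1 but carries 2,6-dichlorophenyl in place of ethoxycarbonyl on the aromatic carbon next to the ring nitrogen (2,6-dichlorophenyl in place of ethoxycarbonyl on an aromatic carbon). Within the data shown here, no measured step changes that place. Among the measured compounds shown here, the only guide is therefore a 2.6-fold higher number from compound 1 to compound 2 (0.42 log units; beyond the scatter) as a modest step made elsewhere on the shared core, and it offers no direction for the new change. With so little to go on, the estimate stays close to compound 1 and only a small shift is expected. The expected step is a 1.3-fold lower number from compound 1 to compound 3 (0.12 log units; within the scatter) with no firm direction behind it, and a wide range is kept open on both sides. Compound 3 is estimated at 25000 nM with an expected range from 8000 nM to 80000 nM in this assay when it is measured.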

Compound 3, half-maximal effective concentration: > 150000 nM
Compound 3 was reported as a limit (the forecaster's own chance of this, stated with the estimate: 15%); at least 6.0-fold (0.77 log units) between middle value and limit.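

At the aromatic carbon next to the ring nitrogen, the exchange of ethoxycarbonyl for 2,6-dichlorophenyl gives, in this assay, an at least 4.5-fold higher number from compound 1 to compound 3 (0.65 log units; beyond the scatter). The reading for compound 3 is a limit of the assay and not a number: the limit of > 150000 nM in this assay, at which 1 of the 3 values shown sits. Within the data shown here, the earlier step, a 2.6-fold higher number from compound 1 to compound 2 (0.42 log units; beyond the scatter), concerned only the methoxy group, so this result is the first to show that the place carrying ethoxycarbonyl also matters in this assay, and that this exchange moves the number upward, with a group lacking hydrogen-bond acceptors and carrying an aromatic ring standing where the ester stood.

The compounds shown do not separate the contribution of the new ring from that of its two chlorines, or either of these from the loss of ethoxycarbonyl, and an unsubstituted phenyl, a carboxylic acid or an amide at this place would bear on that question. On these data alone, it also remains open whether the step between methoxy and hydrogen would hold with 2,6-dichlorophenyl in place, since only a limit stands for compound 3.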